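Swapping phenyl for thiophen-2-yl on the chloro compound

This account rests on a few compounds, and the source may have more. Where it says the series, first, only, none or still open, it means among the compounds named here.

Compound 1 `OC[C@H]1O[C@@H](n2cc(F)c3c(-c4ccccc4)ncnc32)[C@H](O)[C@@H]1O` gives 3100 nM
Compound 2 `OC[C@H]1O[C@@H](n2cc(F)c3c(-c4cccs4)ncnc32)[C@H](O)[C@@H]1O` gives 270 nM
Compound 3 `OC[C@H]1O[C@@H](n2cc(Cl)c3c(-c4ccccc4)ncnc32)[C@H](O)[C@@H]1O` gives 910 nM
Compound 4 `OC[C@H]1O[C@@H](n2cc(Cl)c3c(-c4cccs4)ncnc32)[C@H](O)[C@@H]1O` has no value yet

All three numbers come from a functional assay on CCRF-CEM cells (Homo sapiens) for cytotoxicity, read by XTT assay, with a stated time of 3 days (a lower number here means a stronger inhibitor, a higher number a weaker inhibitor), and compound 3 stands in the middle of them, clearly below compound 1 and clearly above compound 2. Compound 4 differs from compound 3 by one group thiophen-2-yl in place of phenyl on an aromatic carbon and in words this is thiophen-2-yl in place of phenyl on an aromatic carbon. The same swap has been measured once, with fluoro rather than chloro on the shared core. That large step was an 11-fold lower number from compound 1 to compound 2 (1.06 log units; beyond the scatter) and it is the main guide here. The modest step of a 3.4-fold lower number from compound 1 to compound 3 (0.53 log units; beyond the scatter) shows what chloro in place of fluoro did, and it points the same way when applied to compound 2 (270 nM). A single example cannot show that the swap behaves alike with chloro, so a large step to a lower number in this assay is expected, though with caution. The expected change is a 9.6-fold lower number from compound 3 to compound 4 (0.98 log units; beyond the scatter) by this estimate. Compound 4 is estimated at 95 nM with an expected range of 35 nM to 250 nM for its measurement.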

Compound 4, half-maximal inhibitory concentration: 2700 nM
Compound 4: the middle estimate sits 28-fold (1.45 log units) below what was measured, outside the stated range (above it).
By their numbers in this assay, from the lowest: compound 2; then compound 3; then compounds 4 and 1 (each within the scatter of the next).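

Thiophen-2-yl in place of phenyl at this position has no fixed effect: on the chloro compound it gives a 3.0-fold higher number from compound 3 to compound 4 (0.47 log units; beyond the scatter), opposite in direction to the step seen with fluoro on the shared core: the same change on two cores in this assay, an 11-fold lower number (1.06 log units; beyond the scatter) from compound 1 to compound 2 and a 3.0-fold higher number (0.47 log units; beyond the scatter) from compound 3 to compound 4, 34-fold (1.53 log units) apart, beyond the scatter of two such steps The halogen change depends on its partner in the same way, since with thiophen-2-yl in place it gives a 10-fold higher number from compound 2 to compound 4 (1.00 log units; beyond the scatter), whereas with phenyl it lowered the number: the same change on two cores in this assay, a 3.4-fold lower number (0.53 log units; beyond the scatter) from compound 1 to compound 3 and a 10-fold higher number (1.00 log units; beyond the scatter) from compound 2 to compound 4, 34-fold (1.53 log units) apart, beyond the scatter of two such steps The two changes therefore do not simply add up, and the pairing of fluoro with thiophen-2-yl in compound 2 gives the lowest number of the four.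

The compounds shown do not explain this reversal. As far as these compounds go, it also stays open whether furan-2-yl or an amine at this position, or bromo in place of chloro, would behave like the fluoro or the chloro series.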